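The compounds below may be only part of what the source reports. "The series", "measured", "known", "first", "only" and "open" are said of these compounds alone.

Compound 2 `COc1cc(Cl)cc(-c2nn(-c3cccc(NC(=O)Nc4ccc(Cl)c(C(F)(F)F)c4)c3)cc2-c2ccncc2)c1` gives 18.1% in a functional assay on HCC 2998 cells (Homo sapiens) for inhibition, read by sulforhodamine B assay, with a stated time of 48 h, tested at 10 uM (on this read-out lower numbers stand for a stronger effect and higher numbers for a weaker effect at the one concentration tested), the lowest of the two numbers in hand. Among the compounds with values here, its nearest neighbour, compound 1 `COc1cc(Cl)cc(-c2nn(-c3cccc(NC(=O)c4ccc(Cl)c(Cl)c4)c3)cc2-c2ccncc2)c1`, gives 77.8%; the one measured step, a number 59.7 percentage points lower from compound 1 to compound 2 (beyond the scatter), lies beyond the scatter and counts as large. That step, however, exchanges the whole (4-chloro-3-(trifluoromethyl)phenyl)amino group for 3,4-dichlorophenyl on the carbonyl carbon, so it does not single out the smaller change now in question.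

Compound 3 `COc1cc(Cl)cc(-c2nn(-c3cccc(NC(=O)Nc4ccc(Cl)c(Cl)c4)c3)cc2-c2ccncc2)c1` differs from compound 2 only in that (chloro in place of trifluoromethyl on an aromatic carbon). Within the data shown here, the change sits on an aromatic carbon of a six-membered aromatic ring of carbon only, ortho to a chloro group and meta to a large group, and no measured pair isolates it: the replacement of trifluoromethyl by chloro is part of the step from compound 1 to compound 2 but is entangled there with the change at the carbonyl carbon. Among the measured compounds shown here, with no step bearing on it alone, compound 3 is expected to stay close to compound 2, so a number 9.9 percentage points higher from compound 2 to compound 3 (within the scatter) is estimated to lie within the scatter, and compound 3 is expected to read about 28% in this assay, between 10% and 55%.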

Compound 3, a percentage reported as activity, at one concentration (the size of the read-out at that concentration, not a potency): 26.7%
Compound 3: the middle estimate sits 1.3 percentage points above what was measured; the range from low to high includes it.
By their numbers in this assay, from the lowest: compounds 2 and 3 (each within the scatter of the next); then compound 1.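

In this assay, chloro in place of trifluoromethyl on this aromatic carbon, ortho to a chloro group and meta to a large group, gives a number 8.6 percentage points higher from compound 2 to compound 3 (within the scatter), so the two groups cannot be told apart at this position by this read-out. Compound 3 also separates the two changes that were entangled earlier: (3,4-dichlorophenyl)amino in place of 3,4-dichlorophenyl on a carbonyl carbon gives a number 51.1 percentage points lower from compound 1 to compound 3 (beyond the scatter). Among these three compounds, the large difference therefore goes with the change on the carbonyl carbon and not with the exchange of trifluoromethyl for chloro. Nothing available accounts for either step.

On these data alone, it remains open whether a hydrogen, a methyl, a methoxy or a nitrile on the same aromatic carbon would also read within the scatter of chloro and trifluoromethyl. As far as these compounds go, it is equally open whether the gain depends on the amino nitrogen itself, which an oxygen or an N-methyl amino group on the carbonyl carbon could test, and whether these readings at a single concentration would carry over to full concentration-response curves.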